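Amide to urea on the shared core

The compounds below may be only part of what the source reports. "The series", "measured", "known", "first", "only" and "open" are said of these compounds alone.

Compound 1 `COc1cc(-c2nn(-c3cccc(NC(=O)c4ccc(Cl)c(C(F)(F)F)c4)c3)cc2-c2ccncc2)ccc1Cl` carries an amide on the shared core. In a functional assay on RXF 393 cells (Homo sapiens) for inhibition, read by sulforhodamine B assay, with a stated time of 48 h (on this read-out lower numbers stand for higher toxicity in this test and higher numbers for lower toxicity in this test), compound 1 reaches only the limit of the measurement, > 32500 nM. Among the measured compounds shown here, it is the one compound of the three measured that sits at this limit, (the limit of > 32500 nM in this assay, at which 1 of the 3 values shown sits). Compound 3 `COc1cc(-c2nn(-c3cccc(NC(=O)Nc4cccc(C(F)(F)F)c4)c3)cc2-c2ccncc2)ccc1Cl` gives 4830 nM in this assay, and compound 2 `O=C(Nc1cccc(-n2cc(-c3ccncc3)c(-c3ccc(Cl)c(O)c3)n2)c1)Nc1cc(C(F)(F)F)cc(C(F)(F)F)c1` gives 10700 nM in this assay.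

Compound 4 `COc1cc(-c2nn(-c3cccc(NC(=O)Nc4ccc(Cl)c(C(F)(F)F)c4)c3)cc2-c2ccncc2)ccc1Cl` has not yet been measured. It differs from compound 1 in one place: (4-chloro-3-(trifluoromethyl)phenyl)amino in place of 4-chloro-3-(trifluoromethyl)phenyl on a carbonyl carbon. For the measured compounds named here, the one measured step that bears on this change is an at least 6.7-fold lower number from compound 1 to compound 3 (0.82 log units; beyond the scatter), where the amide likewise becomes a urea, though with (3-(trifluoromethyl)phenyl)amino entering rather than (4-chloro-3-(trifluoromethyl)phenyl)amino. Compound 2, a urea as well, likewise gives a measured number rather than a limit. Compound 4 is therefore expected to move in the same direction as compound 3, with an estimated step of an at least 6.5-fold lower number from compound 1 to compound 4 (0.81 log units; beyond the scatter). The estimated value for compound 4 in this assay is 5000 nM, with a range from 1500 nM to 16000 nM.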

Compound 4, concentration lethal to 50% of the cells: > 32500 nM
Compound 4: only a limit was reported (the forecaster's own chance of this, stated with the estimate: 10%); middle value at least 6.5-fold (0.81 log units) from the limit.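

Compound 4 reaches only a limit of the measurement in this assay: the limit of > 32500 nM in this assay, at which 2 of the 4 values shown sit. The change from amide to urea with the 4-chloro-3-(trifluoromethyl)phenyl group kept therefore gives a step that cannot be read, as compound 1 and compound 4 both stand at limits. Among the ureas, chloro in place of hydrogen on an aromatic carbon gives an at least 6.7-fold higher number from compound 3 to compound 4 (0.82 log units; beyond the scatter), so the measured number of compound 3 does not carry over to every urea on the shared core.

The compounds shown leave open what the real values behind the two limits are, and with them whether the urea changes anything at all when this group stays. Going by these compounds, it also remains open whether an amine or a carboxylic acid in place of the chloro on that aromatic carbon would give a measured number in this assay.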